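Dropping one chlorine from a dichlorophenyl group

A few compounds are considered here, and "the series" means these few. Any claim that something is new, unique, unknown or untested is made for them only; others in the source may bear on it.

Compound 1 `Cn1cncc1C(OCc1ccc(C#N)nc1-c1ccc(OC(F)(F)F)cc1)c1ccc(C#N)cc1` and compound 2 `Cn1cncc1C(OCc1ccc(C#N)nc1-c1cc(Cl)cc(Cl)c1)c1ccc(C#N)cc1` share the same core and differ only in the aryl group attached to it. In an assay on isolated protein (Bos taurus) for inhibition of geranylgeranyl transferase type-1 subunit beta (Homo sapiens) (a lower number here means a stronger inhibitor, a higher number a weaker inhibitor), compound 1 gives 1200 nM, and compound 2 gives 1400 nM. The step of a 1.2-fold higher number from compound 1 to compound 2 (0.07 log units; within the scatter) swaps 4-(trifluoromethoxy)phenyl for 3,5-dichlorophenyl and lies within the scatter. Among the measured compounds shown here, compound 2 thus holds the highest of the two numbers measured so far, but its only neighbour, compound 1, sits within the scatter of it, so no order between the two can be read.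

Compound 3 `Cn1cncc1C(OCc1ccc(C#N)nc1-c1cccc(Cl)c1)c1ccc(C#N)cc1` is the next step: hydrogen in place of chloro on an aromatic carbon, so that 3,5-dichlorophenyl becomes 3-chlorophenyl. For the measured compounds named here, no measured step removes a chloro group at this place. Going by the values given here, the only step that touches this aryl ring, a 1.2-fold higher number from compound 1 to compound 2 (0.07 log units; within the scatter), shows that a sizeable exchange of the whole group left the half-maximal inhibitory concentration within the scatter, which argues for a modest effect here too. The step of a 1.1-fold higher number from compound 2 to compound 3 (0.03 log units; within the scatter) is therefore expected to stay within the scatter. Compound 3 is estimated at 1500 nM, with a range from 700 nM to 3500 nM.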

Compound 3, half-maximal inhibitory concentration: 1700 nM
Estimate against measurement, compound 3: 1.1-fold (0.05 log units) below; the range from low to high includes it.
By their numbers in this assay, from the lowest: compounds 1, 2 and 3 (each within the scatter of the next).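

In this assay, taking away one chloro group gives a 1.2-fold higher number from compound 2 to compound 3 (0.08 log units; within the scatter), so 3,5-dichlorophenyl and 3-chlorophenyl cannot be told apart here, and the second chlorine on this ring shows no measurable contribution. The comparison of the remaining pair gives a 1.4-fold higher number from compound 1 to compound 3 (0.15 log units; within the scatter), so 3-chlorophenyl and 4-(trifluoromethoxy)phenyl cannot be told apart either, and all three aryl groups now lie within the scatter of one another. No measurement at hand offers an explanation for this flat picture.

Every aryl group shown still carries at least one substituent, so it remains open how a plain phenyl ring with no chloro group would compare with 3-chlorophenyl. Going by these compounds, it also remains open whether a different kind of group on this ring, such as an amine or a carboxylic acid, would move the half-maximal inhibitory concentration beyond the scatter in either direction.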